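This account rests on a few compounds, and the source may have more. Where it says the series, first, only, none or still open, it means among the compounds named here.

Compound 1 `Nc1nc(O)c2c(n1)n(C1OC(CO)[C@@H](O)[C@H]1O)c(=O)n2C/C=C/c1ccccc1` gives 5% in a functional assay on the whole organism with Mus musculus as the target (on this read-out higher numbers stand for larger maximal responses and lower numbers for smaller maximal responses), the lowest of the two numbers shown; compound 2 `C=CCn1c(=O)n(C2C[C@H](O)C(CO)O2)c2nc(N)nc(O)c21` gives 131%, which lies beyond the scatter above it. Compound 3 `CCCCCCCCCCn1c(=O)n(C2OC(CO)[C@@H](O)[C@H]2O)c2nc(N)nc(O)c21` differs from compound 1 in one place: nonyl in place of 2-phenylethenyl on a saturated chain carbon bound to an aromatic nitrogen. For the measured compounds named here, no step between two measured compounds matches this change, so its size is uncertain. An upward step from compound 1 to compound 3 is expected, of the size a number 40 percentage points higher from compound 1 to compound 3 (beyond the scatter), beyond the scatter. Compound 3 is therefore expected to reach about 45%, within a range from 5% to 110%.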

Compound 3, largest response reached (reported as maximal response), in percent of the reference or control that the assay uses: 0%
For compound 3 the middle estimate is 45 percentage points above the measured one; measured number outside the range, below it.
By their numbers in this assay, from the lowest: compounds 3 and 1 (each within the scatter of the next); then compound 2.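

In this assay, putting nonyl in place of 2-phenylethenyl on a saturated chain carbon bound to an aromatic nitrogen gives a number 5 percentage points lower from compound 1 to compound 3 (within the scatter), the first step read at this place. The six-membered aromatic ring and the double bond outside it can therefore leave, with a ring-free chain entering, without a change beyond the scatter. Nothing given here accounts for this result.

On these data alone, whether a butyl chain at this place would give a different response remains open. So does the effect of a chain ending in an amine or a carboxylic acid.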